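The compounds below may be only part of what the source reports. "The series", "measured", "known", "first", "only" and "open" are said of these compounds alone.

Compound 1 `O=c1c(CSC(=S)N2CCCCC2)coc2cc(Cl)ccc12` is one of a pair tested in a functional assay on MDA-MB-435S cells (Homo sapiens) for antiproliferative activity, read by MTT assay, with a stated time of 72 h (on this read-out lower numbers stand for stronger inhibition and higher numbers for weaker inhibition), where compound 1 gives 240 nM, the lowest of the two numbers seen. Among the measured compounds shown here, its partner compound 2 `O=c1c(CSC(=S)N2CCCC2)coc2cc(Cl)ccc12` gives 6400 nM, and the only change between them, pyrrolidin-1-yl in place of piperidin-1-yl on a thiocarbonyl carbon, produced a 27-fold higher number from compound 1 to compound 2 (1.43 log units; beyond the scatter). Compound 3 `O=c1c(CSC(=S)N2CCCCC2)coc2ccccc12` differs from compound 1 at another place: hydrogen in place of chloro on an aromatic carbon. For the measured compounds named here, no measured step touches this position, so no step is directly comparable. Compound 3 is therefore expected, with wide uncertainty, to give 600 nM, within 150 nM to 2500 nM, which means a step of a 2.5-fold higher number from compound 1 to compound 3 (0.40 log units; beyond the scatter).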

Compound 3, half-maximal inhibitory concentration: 470 nM
The estimate for compound 3 lay 1.3-fold (0.11 log units) above the measured number; the range from low to high includes it.
By their numbers in this assay, from the lowest: compounds 1 and 3 (each within the scatter of the next); then compound 2.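

Swapping chloro for hydrogen on this aromatic carbon gives a 2.0-fold higher number from compound 1 to compound 3 (0.29 log units; within the scatter) in this assay, so compound 1 and compound 3 cannot be told apart. The chloro is therefore not required at this position for activity in the nanomolar range seen here, whereas the ring change at the other end of the molecule gave a 27-fold higher number from compound 1 to compound 2 (1.43 log units; beyond the scatter). Nothing available explains this result.

On these data alone, whether a larger group at this position, such as methoxy or an amine, would be tolerated remains open. So does whether hydrogen and chloro would also match when pyrrolidin-1-yl sits on the thiocarbonyl carbon.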